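Swapping Trifluoromethyl for Iodo: What to Expect

A few compounds are considered here, and "the series" means these few. Any claim that something is new, unique, unknown or untested is made for them only; others in the source may bear on it.

Of the compounds shown here, three on a shared core have been measured in a functional assay on FM3A cells (Mus musculus) for antiproliferative activity; on this read-out higher numbers stand for weaker inhibition and lower numbers for stronger inhibition. Compound 1 `COc1cc(C(=O)c2sc(-c3ccc(F)cc3)cc2N)cc(OC)c1OC` gives 16 nM, compound 2 `COc1cc(C(=O)c2sc(-c3ccc(C(F)(F)F)cc3)cc2N)cc(OC)c1OC` gives 540 nM, and compound 3 `COc1cc(C(=O)c2sc(-c3cc(OC)c(OC)c(OC)c3)cc2N)cc(OC)c1OC` gives 3500 nM. Compound 2 thus holds the second highest of the three numbers, beyond the scatter from both neighbours: compound 3 stands above it and compound 1 well below it.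

Compound 4 `COc1cc(C(=O)c2sc(-c3ccc(I)cc3)cc2N)cc(OC)c1OC` has not yet been measured. It differs from compound 2 in one place: iodo in place of trifluoromethyl on an aromatic carbon. For the measured compounds named here, the one measured step that bears on this aromatic carbon is a 34-fold higher number from compound 1 to compound 2 (1.53 log units; beyond the scatter), which shows that trifluoromethyl there carries a markedly higher number than fluoro. Iodo is, like fluoro, a halogen, so a move back toward the lower number of compound 1 appears plausible, though no measured pair contains iodo itself and a full return cannot be assumed. For compound 4 in this assay a step of a 4.5-fold lower number from compound 2 to compound 4 (0.65 log units; beyond the scatter) is therefore expected, toward a lower number. Compound 4 is estimated at 120 nM, with a range from 25 nM to 600 nM.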

Compound 4, half-maximal inhibitory concentration: 420 nM
Beside the measured number, compound 4's estimate is 3.5-fold (0.54 log units) below it; low and high end bracket the measured number.
By their numbers in this assay, from the lowest: compound 1; then compounds 4 and 2 (each within the scatter of the next); then compound 3.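

At this aromatic carbon in this assay, iodo does not keep the low number of fluoro: the change gives a 26-fold higher number from compound 1 to compound 4 (1.42 log units; beyond the scatter) and so sharing the class of halogens is not enough to hold the number of compound 1. Iodo in place of trifluoromethyl gives a 1.3-fold lower number from compound 2 to compound 4 (0.11 log units; within the scatter) and so this read-out does not separate these two groups, which leaves fluoro as the only one of the three groups at this carbon with a number as low as that of compound 1. Nothing at hand explains why fluoro stands apart from iodo and trifluoromethyl here.

On these data alone, it remains open whether chloro and bromo on this same carbon would fall with fluoro, with iodo or somewhere in the wide gap between them, which would show whether the number climbs gradually along the halogens or jumps after fluoro. Also open, as far as these compounds go, is how groups outside this set, such as an amine, a nitrile or a carboxylic acid, would read at this carbon on the shared core.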